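This account rests on a few compounds, and the source may have more. Where it says the series, first, only, none or still open, it means among the compounds named here.

Compound 1 `O=C(O)c1ccc(-c2cnc(C(=O)CCc3ccc(Oc4ccccc4)cc3)o2)nc1` is one of three closely related compounds that share a common core and differ at a single point on that core. In an assay for inhibition of Fatty-acid amide hydrolase 1 (Rattus norvegicus) (on this read-out higher numbers stand for weaker inhibition and lower numbers for stronger inhibition), compound 1 gives 33 nM, the highest number among the three and hence the weakest inhibition. Compound 2 `NC(=O)c1cnc(C(=O)CCc2ccc(Oc3ccccc3)cc2)o1` gives 6.6 nM in this assay, and compound 3 `N#Cc1cnc(C(=O)CCc2ccc(Oc3ccccc3)cc2)o1` gives 0.8 nM. The steps among them are all beyond the scatter: a 5.0-fold lower number from compound 1 to compound 2 (0.70 log units; beyond the scatter), a 41-fold lower number from compound 1 to compound 3 (1.62 log units; beyond the scatter), and an 8.3-fold lower number from compound 2 to compound 3 (0.92 log units; beyond the scatter).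

Compound 4 `O=C(O)c1ccc(-c2cnc(C(=O)CCc3ccc(COc4ccccc4)cc3)o2)nc1` keeps the group that compound 1 carries on its core and instead changes the other end of the molecule: phenoxymethyl in place of phenoxy on an aromatic carbon. None of the three measured steps touches this part of the structure, so they give no direct guide to the size or direction of the step from compound 1 to compound 4 in this assay. The expectation therefore rests on compound 1 alone, with a wide allowance for either direction. On that basis the step of a 1.8-fold higher number from compound 1 to compound 4 (0.26 log units; within the scatter) is expected to stay close to the scatter. Compound 4 is estimated to give 60 nM in this assay, within a range from 12 nM to 300 nM.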

Compound 4, inhibition constant: 4.6 nM
Compound 4: the middle estimate sits 13-fold (1.12 log units) above what was measured; measured number below the stated range.
By their numbers in this assay, from the lowest: compound 3; then compounds 4 and 2 (each within the scatter of the next); then compound 1.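

The end of the molecule away from the shared core also moves the number, not only the group on the core: in this assay, phenoxymethyl in place of phenoxy, on the aromatic carbon para to a large group, gives a 7.2-fold lower number from compound 1 to compound 4 (0.86 log units; beyond the scatter) and so stronger inhibition. The change is small on paper, with 8 heavy atoms in place of 7 and the same count of hydrogen-bond donors, acceptors and charge, yet the step lies beyond the usual scatter. Nothing measured for these compounds accounts for that gain.

As far as these compounds go, it remains open whether phenoxymethyl gives a similar step when the core carries cyano or carbamoyl in place of 5-carboxypyridin-2-yl. Also open, from the compounds shown here alone, is how a longer chain, such as phenoxyethyl, or an amine in place of the ether oxygen would behave here.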